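Methyl to ethoxy on the benzyl ether of compound 2

The compounds below may be only part of what the source reports. "The series", "measured", "known", "first", "only" and "open" are said of these compounds alone.

Measured so far in a functional assay on PC-3 cells (Homo sapiens) for cytotoxicity, read by sulforhodamine B assay; a lower number here means that less compound is tolerated, a higher number that more compound is tolerated:
compound 1, `COc1cccc(OC)c1OCCNCCOc1ccccc1OCc1ccccc1`, gives 193000 nM
compound 2, `COc1cccc(OC)c1OCCNCCOc1ccccc1OCc1ccc(C)cc1`, gives 61700 nM

Within the data shown here, compound 2 stands at the lower of the two numbers in this assay; the only neighbour, compound 1, lies higher by a 3.1-fold lower number from compound 1 to compound 2 (0.50 log units; beyond the scatter). Compound 3, `CCOc1ccc(COc2ccccc2OCCNCCOc2c(OC)cccc2OC)cc1`, differs from compound 2 by ethoxy in place of methyl on an aromatic carbon. Among the measured compounds shown here, no measured pair shows this exact exchange. For the measured compounds named here, the one step known, a 3.1-fold lower number from compound 1 to compound 2 (0.50 log units; beyond the scatter), concerns the same place on the ring and was modest, so a group larger than methyl at that place is a departure from what has been tried. Going by the values given here, with only that single step to go on, a change of modest size at most is expected, with the direction uncertain and no step beyond the scatter the likeliest outcome. For compound 3 the number in this assay is therefore estimated at 45000 nM, within 15000 nM to 140000 nM. The expected step is a 1.4-fold lower number from compound 2 to compound 3 (0.14 log units; within the scatter).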

Compound 3, concentration lethal to 50% of the cells: 51300 nM
The estimate for compound 3 lay 1.1-fold (0.06 log units) below the measured number; the measured number falls inside the stated range.
By their numbers in this assay, from the lowest: compounds 3 and 2 (each within the scatter of the next); then compound 1.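

At the aromatic carbon para to a large group, the exchange of methyl for ethoxy gives a 1.2-fold lower number from compound 2 to compound 3 (0.08 log units; within the scatter) in this assay, so the added oxygen and longer substituent leave the number indistinguishable from that of the methyl compound. Replacing hydrogen at the same place with ethoxy gives a 3.8-fold lower number from compound 1 to compound 3 (0.58 log units; beyond the scatter), so compounds 2 and 3 both stand apart from compound 1 while remaining inseparable from each other. No supporting evidence bears on why this position tolerates the exchange.

Open, on these data alone, is whether a longer chain such as butoxy at this carbon would stay within the scatter of compound 2 or move beyond it. Also open, as far as these compounds go, is how an amine, a carboxylic acid or a chlorine atom at the same place would read in this assay.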